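Acyl chain extension on the histamine-like guanidine series

The source may report more compounds than this note shows. Statements on the series, on what has been measured and on what is new or still open speak of the compounds shown alone.

Compound 1 `CCC(=O)/N=C(\N)NCCCc1c[nH]cn1` carries a propanoyl group on the acylguanidine and in a functional assay on cardiac atrium for agonist activity at histamine H2 receptor (Cavia porcellus) (on this read-out higher numbers stand for an effect only at larger amounts of compound and lower numbers for an effect already at smaller amounts), compound 1 gives 302 nM, the second highest of the three numbers measured. Compound 2 `CC(=O)/N=C(\N)NCCCc1c[nH]cn1` gives 813 nM and compound 3 `CC(C)C(=O)/N=C(\N)NCCCc1c[nH]cn1` gives 110 nM. The step of a 2.7-fold higher number from compound 1 to compound 2 (0.43 log units; beyond the scatter) removes a methyl from the chain carbon bound to the carbonyl; the step of a 2.7-fold lower number from compound 1 to compound 3 (0.44 log units; beyond the scatter) adds one there; the step of a 7.4-fold lower number from compound 2 to compound 3 (0.87 log units; beyond the scatter) runs the other way over both. Among the compounds with values here, in each case more carbon on the acyl group goes with a lower number, and no measured compound goes against this.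

Compound 4 `CCCC(=O)/N=C(\N)NCCCc1c[nH]cn1` differs from compound 1 by methyl in place of hydrogen on a saturated chain carbon, two bonds along the chain from a carbonyl carbon. The added methyl sits one bond further out than in compound 3, so the change most like it is the step from compound 1 to compound 3, with the step from compound 1 to compound 2 as the reverse case. A modest lowering beyond the scatter is therefore expected: the step of a 1.8-fold lower number from compound 1 to compound 4 (0.25 log units; within the scatter) is the estimate. For compound 4 the expected value is 170 nM, with a range from 70 nM to 420 nM.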

Compound 4, half-maximal effective concentration: 186 nM
Compound 4: middle estimate off by 1.1-fold (0.04 log units), on the low side; low and high end bracket the measured number.
By their numbers in this assay, from the lowest: compounds 3, 4 and 1 (each within the scatter of the next, the first and the last beyond it); then compound 2.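

Methyl in place of hydrogen on a saturated chain carbon, two bonds along the chain from a carbonyl carbon, gives a 1.6-fold lower number from compound 1 to compound 4 (0.21 log units; within the scatter), so in this assay this added carbon does not separate the two compounds, whereas the same replacement on the chain carbon bound to a carbonyl carbon gave a 2.7-fold lower number from compound 1 to compound 3 (0.44 log units; beyond the scatter). Propyl and isopropyl on a carbonyl carbon are likewise not told apart, with a 1.7-fold higher number from compound 3 to compound 4 (0.23 log units; within the scatter), while ethyl in place of hydrogen on the chain carbon bound to a carbonyl carbon gives a 4.4-fold lower number from compound 2 to compound 4 (0.64 log units; beyond the scatter). Nothing at hand accounts for these steps.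

On these data alone, whether a longer chain, such as butyl on the carbonyl carbon, would give a number beyond the scatter of compound 4 stays open. Also open, as far as these compounds go, is how an amine or a carboxylic acid on that chain would read.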